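Two analogues on one core and an ester yet to be tested

The source may report more compounds than this note shows. Statements on the series, on what has been measured and on what is new or still open speak of the compounds shown alone.

Measured so far:
Compound 1, `Cc1nc2c(CCc3ccccc3)cccn2c1N`: 47%
Compound 2, `Cc1nc2c(CCc3ccccc3)cccn2c1O`: 32%

Both compounds were tested in a functional assay on the whole organism with Rattus norvegicus as the target, at a dose of 40 mg/kg by the intraperitoneal route; on this read-out lower numbers stand for less inhibition and higher numbers for more inhibition at the one dose given (going by the name of the read-out). Compound 1 gives 47%, and compound 2 gives 32%, the lower of the two numbers. Among the measured compounds shown here, the one step between them, a number 15 percentage points lower from compound 1 to compound 2 (beyond the scatter), shows that exchanging the amino group on the shared core for a hydroxy group costs a modest amount of inhibition.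

Compound 3, `COC(=O)c1c(C)nc2c(CCc3ccccc3)cccn12`, has not yet been measured in this assay. It differs from compound 2 by one change: methoxycarbonyl in place of hydroxy on an aromatic carbon. For the measured compounds named here, no measured step concerns a methoxycarbonyl group; the only step in hand concerns the amino-to-hydroxy exchange, which is a different change and so gives no direct guide. Because compound 2 sits at 32% and nothing in hand points up or down, the step of a number 3 percentage points higher from compound 2 to compound 3 (within the scatter) is expected to stay within the scatter. For compound 3 the inhibition in this assay is estimated at 35%, with a range from 10% to 60%.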

Compound 3, a percentage reported as inhibition, in the whole organism at one dose (the size of the read-out at that dose, not a potency): 64%
Compound 3: the middle estimate sits 29 percentage points below what was measured; measured number outside the range, above it.
By their numbers in this assay, from the lowest: compound 2; then compound 1; then compound 3.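

Until now this position had only shown a loss, on going from amino to hydroxy; compound 3 shows that the same aromatic carbon, next to the ring nitrogen, can carry a larger group and that inhibition can rise well past both earlier compounds. In this assay, methoxycarbonyl in place of hydroxy gives a number 32 percentage points higher from compound 2 to compound 3 (beyond the scatter), a large step, while methoxycarbonyl in place of amino gives a number 17 percentage points higher from compound 1 to compound 3 (beyond the scatter), a modest one, which makes compound 3 the highest of the three at this one dose. Nothing at hand explains why the methoxycarbonyl group raises the number, so the change can be described but not accounted for.

On these data alone, with only one ester at this position, it remains open whether the gain goes with the carbonyl or with the methoxy part, and how a carboxylic acid, a primary amide or an ethyl ester would compare. Since each compound is read at a single dose, the three numbers also leave open how the compounds would rank at other doses or by another route.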